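From 3-hydroxyphenyl to 3-chlorophenyl: no large step expected

The source may report more compounds than this note shows. Statements on the series, on what has been measured and on what is new or still open speak of the compounds shown alone.

Compound 1 `COC(=O)N1N=C(c2ccccc2)CC1c1cc(OC)c(OC)c(OC)c1`: 2180 nM
Compound 2 `COC(=O)N1N=C(c2ccc(OC)cc2)CC1c1cc(OC)c(OC)c(OC)c1`: 2590 nM
Compound 3 `COC(=O)N1N=C(c2cccc(O)c2)CC1c1cc(OC)c(OC)c(OC)c1`: 1970 nM

In a functional assay on HeLa cells (Homo sapiens) for antiproliferative activity, read by MTT assay, with a stated time of 48 h (on this read-out lower numbers stand for stronger inhibition of growth and higher numbers for weaker inhibition of growth), compound 3 stands level with the other two compounds, within the scatter. The steps read a 1.1-fold lower number from compound 1 to compound 3 (0.04 log units; within the scatter) and a 1.3-fold lower number from compound 2 to compound 3 (0.12 log units; within the scatter). The unmeasured compound 4 `COC(=O)N1N=C(c2cccc(Cl)c2)CC1c1cc(OC)c(OC)c(OC)c1` carries chloro in place of hydroxy on an aromatic carbon, meta to a large group: chloro in place of hydroxy on an aromatic carbon. Among the measured compounds shown here, no measured step makes this exchange directly. The hydroxy step above bears on it, as does a 1.2-fold higher number from compound 1 to compound 2 (0.07 log units; within the scatter), and neither leaves the scatter. The expected step therefore stays within the scatter, with no firm direction, and reads a 1.0-fold higher number from compound 3 to compound 4 (0.01 log units; within the scatter). Compound 4 is expected at 2000 nM, with an estimated range of 800 nM to 5000 nM.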

Compound 4, concentration for 50% growth inhibition: 160 nM
Estimate against measurement, compound 4: 13-fold (1.10 log units) above; the measured number lies below the stated range.
By their numbers in this assay, from the lowest: compound 4; then compounds 3, 1 and 2 (each within the scatter of the next).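

In this assay, chloro at this place on the aromatic ring gives a 12-fold lower number from compound 3 to compound 4 (1.09 log units; beyond the scatter), alongside a 14-fold lower number from compound 1 to compound 4 (1.13 log units; beyond the scatter) and a 16-fold lower number from compound 2 to compound 4 (1.21 log units; beyond the scatter). The hydroxy and methoxy exchanges on this ring had all stayed within the scatter, so the ring does respond to substitution, and the response depends on which group enters. No measurement shown here accounts for the chloro result.

On these data alone, it remains open whether the gain is particular to chloro or would also appear with bromo, methyl or trifluoromethyl at this place. As far as these compounds go, it is equally open whether chloro elsewhere on the ring would give the same result.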